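Chloro for fluoro on a thioether-linked benzamide

The source may report more compounds than this note shows. Statements on the series, on what has been measured and on what is new or still open speak of the compounds shown alone.

Compound 3 `Nc1ccccc1NC(=O)c1ccc(CSc2ccc(F)cc2)cc1` is the most active of the three measured compounds in a functional assay on HCT-116 cells (Homo sapiens) for inhibition, read by CCK-8 assay, with a stated time of 72 h, tested at 8 uM (on this read-out higher numbers stand for more inhibition of growth at the one concentration tested and lower numbers for less inhibition of growth), where compound 3 gives 90.6%. Its nearest measured relative is compound 2 `Nc1ccccc1NC(=O)/C=C/c1ccc(CSc2ccc(F)cc2)cc1`, which in this assay gives 20.2%; the difference between the two cores is not broken down here. Compound 1 `Nc1ccccc1NC(=O)/C=C/c1ccc(CSc2ccc(Cl)cc2)cc1` in this assay gives 3.27%. The step between these two was a number 16.9 percentage points lower from compound 2 to compound 1 (beyond the scatter), and the change made was chloro in place of fluoro on an aromatic carbon.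

The same change is now applied to compound 3 to give compound 4 `Nc1ccccc1NC(=O)c1ccc(CSc2ccc(Cl)cc2)cc1`, which has not yet been tested. The difference is chloro in place of fluoro on an aromatic carbon, and the surroundings of the place are the same words as before. For the measured compounds named here, on the strength of the single earlier step, a drop of similar size is expected, a number 15.6 percentage points lower from compound 3 to compound 4 (beyond the scatter), although a start as high as that of compound 3 leaves less room to fall than compound 2 had. The estimate for compound 4 in this assay is 75%, between 50% and 92%.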

Compound 4, percent growth inhibition at one concentration: 76.6%
Beside the measured number, compound 4's estimate is 1.6 percentage points below it; the measured number falls inside the stated range.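

In this assay, chloro in place of fluoro gave a number 14 percentage points lower from compound 3 to compound 4 (beyond the scatter), and set against the earlier step on the other core, the change carried over with little difference in size: the same change on two cores in this assay, a number 16.9 percentage points lower (beyond the scatter) from compound 2 to compound 1 and a number 14 percentage points lower (beyond the scatter) from compound 3 to compound 4, 2.9 percentage points apart, within the scatter of two such steps. On both cores, then, the fluoro compound stands ahead of its chloro partner by a like amount, and this holds even though compound 4 keeps much of the activity of compound 3 while the earlier pair sits low on the scale. For the compounds shown here, the finding rests on only two pairs tested at one concentration, so it does not extend to other cores and does not say why chloro falls behind fluoro.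

The compounds shown leave open how other groups at the same place, such as bromo, methyl or methoxy, would compare, and where an unsubstituted phenyl would fall relative to the fluoro and chloro compounds. Also open, as far as these compounds go, is whether the change would keep its size if the sulfur of the thioether were replaced by an oxygen or a methylene.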